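Swapping the aryl on the ring nitrogen of a low-activity amide

The source may hold more compounds than are shown below. What is called first, only, known or untested is meant among the compounds shown, and "the series" means these compounds.

Measured compounds:
- Compound 1, `COc1ccccc1N1C(=O)CSC1c1cc(F)cc(C(=O)O)c1`: in a functional assay on U2OS cells (Homo sapiens) for inhibition, read by CCK-8 assay, with a stated time of 72 h, tested at 1 uM (a lower number here means less inhibition, a higher number more inhibition at the concentration tested (going by the name of the read-out)), compound 1 gives 15%.
- Compound 2, `COc1ccc(OC)c(N2C(=O)CSC2c2cccc(C(=O)NCCCCc3ccccc3)c2)c1`: in this assay compound 2 gives 1%.

Compound 2 stands lowest of the two numbers. Its nearest neighbour is compound 1, whose value is higher by an amount beyond the usual scatter, so compound 1 shows more inhibition at this concentration than compound 2. For the measured compounds named here, no single-change step between measured compounds is available, so the effect of changing the aryl group on the ring nitrogen has not been seen directly.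

Compound 3, `O=C(NCCCCc1ccccc1)c1cccc(C2SCC(=O)N2c2cccc(F)c2)c1`, keeps the whole amide side of compound 2 and alters only the aryl group on the ring nitrogen: 3-fluorophenyl in place of 2,5-dimethoxyphenyl on an amide-type nitrogen in a ring. Going by the values given here, with both measured values near the bottom of the scale and no measured step to lean on, the change is expected to be small, either direction, within the scatter: a number 6 percentage points higher from compound 2 to compound 3 (within the scatter). Compound 3 is therefore estimated at 7%, between 0% and 22%.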

Compound 3, a percentage reported as inhibition, at one concentration (the size of the read-out at that concentration, not a potency): 39%
Beside the measured number, compound 3's estimate is 32 percentage points below it, and the stated range ends below it.
By their numbers in this assay, from the lowest: compound 2; then compound 1; then compound 3.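

In this assay, the aryl group on the amide-type nitrogen turns out to matter: 3-fluorophenyl in place of 2,5-dimethoxyphenyl gives a number 38 percentage points higher from compound 2 to compound 3 (beyond the scatter). For the compounds shown here, the amide side stays the same in this pair, so this step gives the first direct reading of this position, and it shows that a change here alone can lift a compound well clear of the bottom of the scale. No measured information on the compounds accounts for this rise.

The swap removes both methoxy groups and adds a fluorine in a single step, so the compounds shown cannot separate the loss of the methoxy groups from the gain of the fluorine. A plain phenyl group, a 3-chlorophenyl group or a 2-methoxyphenyl group on the same nitrogen would help to tell those contributions apart.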